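The source may hold more compounds than are shown below. What is called first, only, known or untested is meant among the compounds shown, and "the series" means these compounds.

Three compounds share one core and differ only in the sulfonyl substituent and in the fluorophenyl groups. In an ADME assay on L02 cells (Homo sapiens) for cytotoxicity, read by MTT assay, with a stated time of 24 h (a higher number here means a weaker inhibitor, a lower number a stronger inhibitor), compound 1 `O=C1/C(=C/c2ccccc2F)CN(S(=O)(=O)c2ccccc2)C/C1=C\c1ccccc1F` gives 17600 nM. In this assay compound 2 `Cc1ccc(S(=O)(=O)N2C/C(=C\c3cccc(F)c3)C(=O)/C(=C/c3cccc(F)c3)C2)cc1` gives 15700 nM. In this assay compound 3 `O=C1/C(=C/c2ccc(F)cc2)CN(S(=O)(=O)c2ccccc2)C/C1=C\c1ccc(F)cc1` gives 18800 nM. Compound 3 holds the highest of the three numbers, but its gaps to compound 1 and to compound 2 both lie within the scatter, so the three values read as a single level and no order among them is drawn.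

Compound 4 `N#Cc1ccc(S(=O)(=O)N2C/C(=C\c3ccc(F)cc3)C(=O)/C(=C/c3ccc(F)cc3)C2)cc1` is not yet measured. It differs from compound 3 in one place: cyano in place of hydrogen on an aromatic carbon. Among the compounds with values here, no measured pair shows this change, so nothing direct is known of its effect. Across compounds 1, 2 and 3 the variation seen leaves the number within the scatter, which gives no ground to expect a move here either. The step from compound 3 to compound 4 is therefore expected to be a 1.1-fold lower number from compound 3 to compound 4 (0.04 log units; within the scatter), no larger than the scatter, in no set direction. Compound 4 is estimated at 17000 nM, in the range 9000 nM to 32000 nM.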

Compound 4, half-maximal inhibitory concentration: 14700 nM
Compound 4: middle estimate off by 1.2-fold (0.06 log units), on the high side; the measured number falls inside the stated range.
By their numbers in this assay, from the lowest: compounds 4, 2, 1 and 3 (each within the scatter of the next).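

Within the data shown here, compound 3 and compound 4 form the first pair that differs in one place. With cyano in place of hydrogen on an aromatic carbon, para to a large group, this assay shows a 1.3-fold lower number from compound 3 to compound 4 (0.11 log units; within the scatter), so this position of the phenylsulfonyl group carries a cyano with no step beyond the scatter. Nothing at hand bears on the reason for this result.

From the compounds shown here alone, it remains open whether this holds only for cyano or also for other groups at the same aromatic carbon, such as an amine, a carboxylic acid or a longer chain. Also open, going by these compounds, is whether cyano gives a similarly small step when the fluorophenyl groups carry their fluorine elsewhere, as in compound 1 and compound 2.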